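From hydroxymethyl to methylcarbamoyl on a shared core

The compounds below may be only part of what the source reports. "The series", "measured", "known", "first", "only" and "open" are said of these compounds alone.

In a physicochemical assay for solubility, with a stated time of 4 h, at pH 2.0 (on this read-out lower numbers stand for lower solubility and higher numbers for higher solubility), compound 3 `Cc1cc(/C=C/C#N)cc(C)c1Oc1cc(Nc2ccc(C#N)cc2)c(N)cc1CO` gives 20.9 ug/mL, the highest of the three numbers measured. Compound 2 `COC(=O)c1cc(N)c(Nc2ccc(C#N)cc2)cc1Oc1c(C)cc(/C=C/C#N)cc1C` gives 1.75 ug/mL, and compound 1 `Cc1cc(/C=C/C#N)cc(C)c1Oc1cc(Nc2ccc(C#N)cc2)c(N)cc1[N+](=O)[O-]` gives 0.29 ug/mL. Compound 4 `CNC(=O)c1cc(N)c(Nc2ccc(C#N)cc2)cc1Oc1c(C)cc(/C=C/C#N)cc1C` carries methylcarbamoyl in place of hydroxymethyl on an aromatic carbon. Among the measured compounds shown here, no methylcarbamoyl compound has been measured, so the evidence is indirect. Both steps arriving at hydroxymethyl are large: a 12-fold higher number from compound 2 to compound 3 (1.08 log units; beyond the scatter) and a 72-fold higher number from compound 1 to compound 3 (1.86 log units; beyond the scatter). The step of a 6.0-fold higher number from compound 1 to compound 2 (0.78 log units; beyond the scatter) is modest. Methoxycarbonyl is the only measured group that also holds a carbonyl, so a large fall is expected in this assay, an estimated 5.2-fold lower number from compound 3 to compound 4 (0.72 log units; beyond the scatter). The estimated value for compound 4 is 4 ug/mL, with an expected range from 1 ug/mL to 15 ug/mL.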

Compound 4, solubility: 8.63 ug/mL
The estimate for compound 4 lay 2.2-fold (0.33 log units) below the measured number, within the range that was stated.
By their numbers in this assay, from the lowest: compound 1; then compound 2; then compound 4; then compound 3.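

In this assay, methylcarbamoyl on this aromatic carbon, para to a (4-cyanophenyl)amino group, ranks above methoxycarbonyl (a 4.9-fold higher number from compound 2 to compound 4 (0.69 log units; beyond the scatter)) and nitro (a 30-fold higher number from compound 1 to compound 4 (1.47 log units; beyond the scatter)) but under hydroxymethyl (a 2.4-fold lower number from compound 3 to compound 4 (0.38 log units; beyond the scatter)). The two carbonyl-bearing groups therefore do not read alike here, and methylamino in place of methoxy on the carbonyl carbon is enough to move the number beyond the scatter. Nothing shown accounts for these steps.

Still open, from the compounds shown here alone, is where a carboxylic acid, an unsubstituted carboxamide or an ethylcarbamoyl group would fall in this order. Also open, going by these compounds, is whether any carbonyl-bearing group at this position can match hydroxymethyl.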